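The compounds below may be only part of what the source reports. "The series", "measured", "known", "first", "only" and "open" are said of these compounds alone.

Of the compounds shown here, two have been measured in an assay on isolated protein for inhibition of Rho-associated protein kinase 2 (Homo sapiens), read by scintillation counting, radiometric assay and 33P incorporation, with a stated time of 40 min, in the presence of a further agent that is not named here; on this read-out higher numbers stand for weaker inhibition and lower numbers for stronger inhibition. Compound 1 `CCCC(=O)Nc1cccc(NC(=O)COc2ccc3c(=O)ccoc3c2)c1` gives 176 nM. Within the data shown here, compound 2 `O=C(COc1ccc2c(=O)ccoc2c1)Nc1cccc(NC(=O)c2ccc(OC(F)(F)F)cc2)c1` gives 77 nM, the lowest of the two numbers, and the step of a 2.3-fold lower number from compound 1 to compound 2 (0.36 log units; beyond the scatter) is the only measured step. Compound 3 `COC(=O)c1ccc(C(=O)Nc2cccc(NC(=O)COc3ccc4c(=O)ccoc4c3)c2)cc1` differs from compound 2 by methoxycarbonyl in place of trifluoromethoxy on an aromatic carbon. The measured step touched the same end of the molecule but swapped a chain for a ring, so it bears only loosely on exchanging one group for another on that ring; a small step in this assay, in either direction or none beyond the scatter, is expected. Compound 3 is therefore estimated at 90 nM, within 40 nM to 200 nM. For compound 3 the expected step is a 1.2-fold higher number from compound 2 to compound 3 (0.07 log units; within the scatter).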

Compound 3, half-maximal inhibitory concentration: 29 nM
Beside the measured number, compound 3's estimate is 3.1-fold (0.49 log units) above it; measured number outside the range, below it.
By their numbers in this assay, from the lowest: compound 3; then compound 2; then compound 1.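

In this assay, the group para to a large group is not a neutral choice: methoxycarbonyl in place of trifluoromethoxy gives a 2.7-fold lower number from compound 2 to compound 3 (0.42 log units; beyond the scatter), a step beyond the scatter. Measured against the propyl chain, 4-(methoxycarbonyl)phenyl gives a 6.1-fold lower number from compound 1 to compound 3 (0.78 log units; beyond the scatter), so the gain from a ring at this end depends on what that ring carries. No measurement here accounts for the difference between the two groups.

On these data alone, whether a carboxylic acid or a primary amide in the same place would give a lower or a higher number stays open. So does the part played by the methyl of the ester.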